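Swapping the Formyl Group on Compound 1

The source may hold more compounds than are shown below. What is called first, only, known or untested is meant among the compounds shown, and "the series" means these compounds.

Compound 1 `C=C1[C@@H](OC(C)=O)C[C@@H]2[C@](C)(COC=O)[C@H](OC(C)=O)CC[C@@]2(C)[C@@H]1C[C@@H](Nc1cccc(F)c1)C1=CCOC1=O`: 23200 nM
Compound 2 `C=C1CC[C@@H]2[C@](C)(CO[Si](C)(C)C(C)(C)C)[C@H](OC(C)=O)CC[C@@]2(C)[C@@H]1C/C=C1/C(=O)OC[C@H]1OC(C)=O`: 3990 nM
Compound 3 `C=C1[C@@H](OC(C)=O)C[C@@H]2[C@](C)(COC=O)[C@H](OC(C)=O)CC[C@@]2(C)[C@@H]1C[C@@H](Nc1ccccc1F)C1=CCOC1=O`: 23600 nM

All three values come from a functional assay on A549 cells (Homo sapiens) for cytotoxicity, read by sulforhodamine B assay; on this read-out lower numbers stand for stronger inhibition and higher numbers for weaker inhibition. Compound 1, at 23200 nM, sits with compound 3 at the high end of these numbers, and compound 2 lies well below both, beyond the scatter. Compound 4 `C=C1[C@@H](OC(C)=O)C[C@@H]2[C@](C)(CO[Si](C)(C)C(C)(C)C)[C@H](OC(C)=O)CC[C@@]2(C)[C@@H]1C[C@@H](Nc1cccc(F)c1)C1=CCOC1=O` keeps the core of compound 1 and changes one group: a group of 7 heavy atoms (6 carbon, 1 silicon; no ring) in place of a group of 2 heavy atoms (1 carbon, 1 oxygen; no ring), on an oxygen on a saturated carbon.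

Among the measured compounds shown here, the only measured step, a 1.0-fold higher number from compound 1 to compound 3 (0.01 log units; within the scatter), moves a fluorine on the aromatic ring and does not touch this oxygen, so no measured step speaks directly to the change. Compound 2, which carries the entering group on such an oxygen, gives 3990 nM, but it also differs from compound 1 elsewhere, so it supports only a cautious expectation of a lower number.

The expected change is a 2.3-fold lower number from compound 1 to compound 4 (0.37 log units; beyond the scatter), and its size is uncertain. For compound 4 the estimated value is 10000 nM, with an expected range from 3000 nM to 28000 nM.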

Compound 4, half-maximal inhibitory concentration: 4060 nM
Compound 4: the middle estimate sits 2.5-fold (0.39 log units) above what was measured; the range from low to high includes it.
By their numbers in this assay, from the lowest: compounds 2 and 4 (each within the scatter of the next); then compounds 1 and 3 (each within the scatter of the next).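

Among the compounds shown here, compound 4 gives the first direct reading at this oxygen on a saturated carbon: in this assay, replacing formyl with the larger silicon-bearing group gives a 5.7-fold lower number from compound 1 to compound 4 (0.76 log units; beyond the scatter). Formyl is therefore not needed to retain activity here, and this change moves the number beyond the scatter, whereas the earlier fluorine shift on the aromatic ring did not. Nothing available explains why the number falls with this change.

The compounds shown leave open whether the silicon itself matters, or whether a free hydroxyl or an all-carbon chain on this oxygen would give a similar number. They also leave open whether the same replacement would give a similar step with the 2-fluorophenyl group of compound 3.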